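Shortening the alkyl chain of compound 1

A few compounds are considered here, and "the series" means these few. Any claim that something is new, unique, unknown or untested is made for them only; others in the source may bear on it.

In a functional assay on MDA-MB-231 cells (Homo sapiens) for inhibition, read by MTT assay, with stated times of 18 h and 4 h (on this read-out higher numbers stand for weaker inhibition and lower numbers for stronger inhibition), compound 1 (`CCCCCCCCOP(=O)(O)OCCSC(=S)N1CCCCC1`) gives 11900 nM and stands lowest of the two numbers. Compound 2 (`CCCCCCCCOP(=O)(O)OCCSC(=S)N1CCCCCC1`) gives 27000 nM in the same read-out. Compound 3 (`CCCCCCOP(=O)(O)OCCSC(=S)N1CCCCC1`) differs from compound 1 by hydrogen in place of ethyl on a saturated chain carbon, six bonds along the chain from an oxygen on an unsaturated carbon with hydrogen in place of ethyl on a saturated chain carbon, six bonds along the chain from an oxygen on an unsaturated carbon. For the measured compounds named here, the only measured step, a 2.3-fold higher number from compound 1 to compound 2 (0.36 log units; beyond the scatter), lies on the thiocarbonyl carbon and not on this chain, so it suggests a size only, and the direction remains tentative. A modest rise is expected in this assay with a 1.8-fold higher number from compound 1 to compound 3 (0.27 log units; within the scatter) as the estimated step. Compound 3 is estimated at 22000 nM with 9000 nM to 55000 nM as the range.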

Compound 3, half-maximal inhibitory concentration: 85000 nM
Compound 3: the middle estimate sits 3.9-fold (0.59 log units) below what was measured; measured number above the stated range.
By their numbers in this assay, from the lowest: compound 1; then compound 2; then compound 3.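

In this assay, the alkyl chain proves to be a second place where the number responds: hydrogen in place of ethyl on a saturated chain carbon, six bonds along the chain from an oxygen on an unsaturated carbon, gives a 7.1-fold higher number from compound 1 to compound 3 (0.85 log units; beyond the scatter). Within this pair, the shorter chain goes with weaker inhibition, so inhibition depends on the chain as well as on the thiocarbonyl substituent. Nothing available explains this step.

From the compounds shown here alone, whether a longer chain would lower the number remains open, as does the effect of an amine or a carboxylic acid at the chain end. Also open, going by these compounds, is whether azepan-1-yl in place of piperidin-1-yl has the same effect on the shorter chain.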